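The source may hold more compounds than are shown below. What is called first, only, known or untested is meant among the compounds shown, and "the series" means these compounds.

Compound 3 `C=CCn1c(=O)/c(=C\c2ccccc2OC)[nH]c(=O)/c1=C\c1ccccc1OC` is one of three compounds that have been put through a functional assay on HeLa cells (Homo sapiens) for cytotoxicity, read by CCK-8 assay, with a stated time of 72 h (a lower number here means a stronger inhibitor, a higher number a weaker inhibitor), and in this assay compound 3 gives 6900 nM. Its nearest neighbour on the numbers is compound 1 `C=CCn1c(=O)/c(=C\c2cccc(Cl)c2)[nH]c(=O)/c1=C\c1ccccc1OC`, which in this assay gives 5500 nM. The step of a 1.3-fold higher number from compound 1 to compound 3 (0.10 log units; within the scatter) is the only one that can be drawn between two measured compounds here, and it shows the two values sitting within the scatter of each other. Compound 2 `COc1ccccc1/C=c1/[nH]c(=O)/c(=C\c2ccccc2OC)n(C)c1=O` is reported in this assay as "not active" (no number reported), with no number attached to it.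

Compound 4 `C=CCn1c(=O)/c(=C\c2ccccc2F)[nH]c(=O)/c1=C\c1ccccc1OC` differs from compound 3 in a single place: fluoro in place of methoxy on an aromatic carbon. Within the data shown here, the one measured step, from compound 1 to compound 3, concerns a different ring of the shared core, so it does not speak to this change, and no measured pair shows what fluoro in place of methoxy does. With nothing pointing either way, the expected step of a 1.0-fold higher number from compound 3 to compound 4 (0.01 log units; within the scatter) is taken as none beyond the scatter. Compound 4 is therefore estimated to give about 7000 nM, with a range from 3000 nM to 16000 nM.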

Compound 4, half-maximal inhibitory concentration: 45000 nM
Compound 4: middle estimate off by 6.4-fold (0.81 log units), on the low side, and the stated range ends below it.
By their numbers in this assay, from the lowest: compounds 1 and 3 (each within the scatter of the next); then compound 4.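

Swapping the group on this ring is not always neutral: with fluoro in place of methoxy on an aromatic carbon, this assay shows a 6.5-fold higher number from compound 3 to compound 4 (0.81 log units; beyond the scatter), so compound 4 is the weaker inhibitor of this pair. The other comparison points the same way, with an 8.2-fold higher number from compound 1 to compound 4 (0.91 log units; beyond the scatter), whereas compound 1 and compound 3 alone, with their different rings, gave values within the scatter of each other and hinted at no such sensitivity. No supporting measurement is available to explain why this single change weakens the result.

From the compounds shown here alone, it remains open whether the loss comes from adding fluoro or from removing methoxy. Going by these compounds, how an amine, a hydroxyl or a longer chain such as ethoxy would behave on this same aromatic carbon also remains unknown.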